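The source may hold more compounds than are shown below. What is called first, only, known or untested is meant among the compounds shown, and "the series" means these compounds.

Compound 1 `CCCCc1c(F)c(N)c2c(=O)cc(-c3ccc(N)c(F)c3)oc2c1F` carries a butyl group on its core and in a functional assay on MCF7 cells (Homo sapiens) for cytotoxicity, read by neutral red uptake, with a stated time of 3 days (a lower number here means a stronger inhibitor, a higher number a weaker inhibitor), gives 8800 nM. Compound 3 `CCCCCCOCc1c(F)c(N)c2c(=O)cc(-c3ccc(N)c(F)c3)oc2c1F` has hexyloxy in place of propyl on a saturated chain carbon bound to an aromatic carbon, and in this assay compound 3 gives 7100 nM, the step being a 1.2-fold lower number from compound 1 to compound 3 (0.09 log units; within the scatter). Compound 2 `Nc1ccc(-c2cc(=O)c3c(N)c(F)c(O)c(F)c3o2)cc1F` has hydroxy in place of butyl on an aromatic carbon, and in this assay compound 2 reaches only a limit, > 10000 nM. Of the three values this one alone sits at the limit of > 10000 nM in this assay, at which 1 of the 3 values shown sits, so compound 2 has no number of its own to set against the others, and the step of an at least 1.1-fold higher number from compound 1 to compound 2 (0.05 log units; that floor lies within the scatter) is a floor that lies within the scatter.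

Compound 4 `CCCCCC(=O)NCc1c(F)c(N)c2c(=O)cc(-c3ccc(N)c(F)c3)oc2c1F` is not yet measured. It differs from compound 2 by ((pentylcarbonyl)amino)methyl in place of hydroxy on an aromatic carbon. The step bearing most directly on this change is the one in which a longer chain likewise replaced hydroxy on an aromatic carbon, an at least 1.4-fold lower number from compound 2 to compound 3 (0.14 log units; that floor lies within the scatter), again a floor within the scatter. Compound 4 is therefore expected to show a step of an at least 1.2-fold lower number from compound 2 to compound 4 (0.09 log units; that floor lies within the scatter), bringing it back toward the numbers of compounds 1 and 3. The estimate for compound 4 in this assay is 8000 nM, with a range from 3500 nM to 20000 nM.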

Compound 4, half-maximal inhibitory concentration: 340 nM
The estimate for compound 4 lay 24-fold (1.37 log units) above the measured number; the whole stated range lies above it.
By their numbers in this assay, from the lowest: compound 4; then compounds 3 and 1 (each within the scatter of the next). At a limit, above all of these: compound 2.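

In this assay, within the data shown here, the earlier compounds showed no clear effect of chain choice at this aromatic carbon, ortho to two fluoro groups, since compound 1 and compound 3 lie within the scatter of each other, whereas the amide-containing chain separates clearly from both: replacing hexyloxy with (pentylcarbonyl)amino on the saturated chain carbon gives a 21-fold lower number from compound 3 to compound 4 (1.32 log units; beyond the scatter), and replacing propyl with the same group gives a 26-fold lower number from compound 1 to compound 4 (1.41 log units; beyond the scatter). The chain of compound 3 and the ((pentylcarbonyl)amino)methyl group of compound 4 are similar enough in extent to show that, among these compounds, the large change goes with the amide link and not with the mere presence of a long chain, and against hydroxy the step is an at least 29-fold lower number from compound 2 to compound 4 (1.46 log units; beyond the scatter). That last step is only a floor, as compound 2 stands at a limit and not at a number of its own: the limit of > 10000 nM in this assay, at which 1 of the 4 values shown sits.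

The compounds shown leave open whether the gain depends on the pentyl part of the amide, which a shorter acetyl or a longer decanoyl group on the same aminomethyl would test. They also leave open whether the amide can give way to a urea, a sulfonamide or a free aminomethyl group.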